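The source may report more compounds than this note shows. Statements on the series, on what has been measured and on what is new or still open speak of the compounds shown alone.

Measured compounds:
compound 1, `O=C(Nc1ccc(S(=O)(=O)N2CCC(O)CC2)cc1)c1ccc([N+](=O)[O-])o1`, which in an assay on CHO-K1 cells for activation of DNA damage-inducible transcript 3 protein (Homo sapiens), read by a luciferase reporter (on this read-out higher numbers stand for an effect only at larger amounts of compound and lower numbers for an effect already at smaller amounts), gives 2000 nM;
compound 2, `O=C(Nc1ccc(S(=O)(=O)N2CCC(F)CC2)cc1)c1ccc([N+](=O)[O-])o1`, for which compound 2 gives 600 nM;
compound 3, `CC1(C)CCN(S(=O)(=O)c2ccc(NC(=O)c3ccc([N+](=O)[O-])o3)cc2)CC1`, for which compound 3 gives 600 nM.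

Compound 3 stands level with compound 2 at the digits shown, and together these two hold the lowest numbers of the three. The step from compound 2 to compound 3 is no change at the digits printed from compound 2 to compound 3 (within the scatter), while the step from compound 1 to compound 3 is a 3.3-fold lower number from compound 1 to compound 3 (0.52 log units; beyond the scatter). The change from compound 1 to compound 2 gives a 3.3-fold lower number from compound 1 to compound 2 (0.52 log units; beyond the scatter).

Compound 4, `CC1(C)CCN(S(=O)(=O)c2ccc(NC(=O)c3cccc([N+](=O)[O-])c3)cc2)CC1`, differs from compound 3 in 3-nitrophenyl in place of 5-nitrofuran-2-yl on a carbonyl carbon. Among the compounds with values here, all three measured steps concern the group attached to the sulfonyl sulfur; the group on the carbonyl carbon is the same in compounds 1, 2 and 3, so no measured step bears on this exchange. The measured steps were modest, but they give no guide to a change at the other end of the molecule, and the direction is open. Since nothing here shows that the nitrofuran can be exchanged without loss, the estimate for compound 4 is placed at 2500 nM, a step of a 4.2-fold higher number from compound 3 to compound 4 (0.62 log units; beyond the scatter), with a wide range from 400 nM to 15000 nM.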

Compound 4, concentration for half-maximal activity: > 80000 nM
Compound 4: a limit, no number (the forecaster's own chance of this, stated with the estimate: 25%); middle value at least 32-fold (1.50 log units) from the limit.
By their numbers in this assay, from the lowest: compounds 2 and 3 (each within the scatter of the next); then compound 1. At a limit, above all of these: compound 4.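

Until now, every measured step lay on the group attached to the sulfonyl sulfur, and those steps were modest or within the scatter. Within the data shown here, the first step on the carbonyl carbon is large: in this assay, 3-nitrophenyl in place of 5-nitrofuran-2-yl gives an at least 130-fold higher number from compound 3 to compound 4 (2.12 log units; beyond the scatter), so in this pair the group on the carbonyl carbon weighs far more than any exchange seen so far on the sulfonyl sulfur. Compound 4 still carries a nitro group on an aromatic ring, which shows that such a group alone does not keep the response, and its reading is a limit of the assay, not a number: the limit of > 80000 nM in this assay, at which 1 of the 4 values shown sits.

The compounds shown leave open whether the loss follows from the six-membered carbon ring replacing the five-membered ring with its hetero atom, or from the changed setting of the nitro group, as compound 4 alters both at once. They also do not tell how a 5-nitrothiophen-2-yl group, a 4-nitrophenyl group, or a furan-2-yl group bearing a nitrile instead of the nitro group would read on the carbonyl carbon.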